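The compounds below may be only part of what the source reports. "The series", "measured", "known", "first", "only" and "open" are said of these compounds alone.

In a physicochemical assay for pharmacokinetics, read by HPLC, in phosphate buffer, at pH 7.4 (on this read-out higher numbers stand for a longer-lived compound and lower numbers for a shorter-lived compound), two compounds of the series have been run so far. Compound 1 `CN(/N=N/c1ccc(C#N)cc1)C(=O)CCc1ccc(O)cc1` gives 86.4 h. Compound 2 `Cc1ccc(/N=N/N(C)C(=O)NCCSc2ccc(O)cc2)cc1` returns only > 240 h, which is a limit of the assay and not a number. Compound 2 thus sits at the limit of > 240 h in this assay, at which 1 of the 2 values shown sits. Among the compounds with values here, no step between measured compounds is defined here, and the two compounds differ in more than one place, so their values show only that compound 2 is the longer-lived of the pair.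

Compound 3 `CCOC(=O)c1ccc(/N=N/N(C)C(=O)NCCSc2ccc(O)cc2)cc1` has not yet been measured. It differs from compound 2 in a single place, (ethoxycarbonyl in place of methyl on an aromatic carbon), on an aromatic carbon of a six-membered aromatic ring of carbon only, para to a large group. Nothing in the measured set isolates this exchange, so no direction can be read from the data, and the change is judged on the structures alone. The step expected in this assay is an at least 1.6-fold lower number from compound 2 to compound 3 (0.20 log units; that floor lies within the scatter), a moderate shortening that remains speculative. Compound 3 is estimated at 150 h, within the range 40 h to 400 h.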

Compound 3, half-life: > 240 h
Compound 3 gave a limit, no number; the forecaster's own chance of this, stated with the estimate: 30%; at least 1.6-fold (0.20 log units) between middle value and limit.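

In this assay compound 3 returns > 240 h as a limit of the assay and not a number. Within the data shown here, compound 2 also stands at a limit, so no step between compound 2 and compound 3 can be read. Still open, as far as these compounds go, is whether ethoxycarbonyl in place of methyl on the aromatic carbon changes the half-life at all, and by how much.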